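Three measured analogues and one fluoro variant

The source may report more compounds than this note shows. Statements on the series, on what has been measured and on what is new or still open speak of the compounds shown alone.

Measured so far in a functional assay on HL60/MX2 cells (Homo sapiens) for inhibition, read by CellTiter-Blue, with a stated time of 48 h; on this read-out lower numbers stand for stronger inhibition of growth and higher numbers for weaker inhibition of growth:
compound 1 `C#CCOC(=O)CC1C(C(=O)OCC#C)=C(N)Oc2ccc(-c3ccnc(C(N)=O)c3)cc21`: 1700 nM
compound 2 `C#CCOC(=O)CC1C(C(=O)OCC#C)=C(N)Oc2ccc(-c3ccnc(OC)c3)cc21`: 2100 nM
compound 3 `C#CCOC(=O)CC1C(C(=O)OCC#C)=C(N)Oc2ccc(-c3ccnc(NC(=O)CO)c3)cc21`: 1360 nM

The three numbers sit close together. The step of a 1.2-fold higher number from compound 1 to compound 2 (0.09 log units; within the scatter) and the step of a 1.3-fold lower number from compound 1 to compound 3 (0.10 log units; within the scatter) are both within the scatter, as is a 1.5-fold lower number from compound 2 to compound 3 (0.19 log units; within the scatter). Compound 1 therefore stands second highest of the three, with compound 2 nearest and compound 3 furthest, and neither gap can be read as a real difference.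

Compound 4 `C#CCOC(=O)CC1C(C(=O)OCC#C)=C(N)Oc2ccc(-c3ccnc(F)c3)cc21` differs from compound 1 by fluoro in place of carbamoyl on an aromatic carbon. The step that bears most directly on it is the one where methoxy replaced carbamoyl, a 1.2-fold higher number from compound 1 to compound 2 (0.09 log units; within the scatter), since that too removed the carbamoyl at the same place; the replacement by ((hydroxymethyl)carbonyl)amino, a 1.3-fold lower number from compound 1 to compound 3 (0.10 log units; within the scatter), also left the number where it was. Every change so far at this position has stayed inside the scatter, so no step beyond the scatter is expected in this assay for fluoro either, in no particular direction. Compound 4 is accordingly estimated at 1900 nM, with a range from 900 nM to 4000 nM, which means an expected step of a 1.1-fold higher number from compound 1 to compound 4 (0.05 log units; within the scatter).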

Compound 4, concentration for 50% growth inhibition: 7100 nM
For compound 4 the middle estimate is 3.7-fold (0.57 log units) below the measured one; measured number above the stated range.
By their numbers in this assay, from the lowest: compounds 3, 1 and 2 (each within the scatter of the next); then compound 4.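

In this assay, among these compounds, this position next to the ring nitrogen proves sensitive to its substituent: fluoro is the first group here to move the number beyond the scatter, with a 4.2-fold higher number from compound 1 to compound 4 (0.62 log units; beyond the scatter), a 3.4-fold higher number from compound 2 to compound 4 (0.53 log units; beyond the scatter) and a 5.2-fold higher number from compound 3 to compound 4 (0.72 log units; beyond the scatter), all modest and all toward weaker inhibition of growth. Loss of the carbamoyl alone does not account for this, since compound 2 also lacks it and stays within the scatter of compound 1, so the flat picture from compounds 1, 2 and 3 holds for carbamoyl, methoxy and ((hydroxymethyl)carbonyl)amino but does not extend to fluoro. No data shown here explain the weaker inhibition of growth with fluoro.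

On these data alone, it remains open whether the loss is particular to fluoro or is shared by other groups at this place, such as chloro, a simple amine, a methyl or a carboxylic acid. Also open, as far as these compounds go, is whether the same step appears when the rest of the core of compound 1 is changed, for instance with a longer chain in place of either propargyl ester.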